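Shrinking the terminal amine ring: compound 2 to compound 3

The source may report more compounds than this note shows. Statements on the series, on what has been measured and on what is new or still open speak of the compounds shown alone.

Going by the values given here, compound 2 `COC(=O)c1cccc(-c2cnc(C(=O)CCc3ccc(-c4ccc(CN5CCCCC5)cc4)cc3)o2)n1` stands as the lowest of the two numbers so far in an assay for inhibition of Fatty-acid amide hydrolase 1 (Rattus norvegicus) (a lower number here means a stronger inhibitor, a higher number a weaker inhibitor), where compound 2 gives 9 nM. Its nearest neighbour, compound 1 `O=C(O)c1cccc(-c2cnc(C(=O)CCc3ccc(-c4ccc(CN5CCCCC5)cc4)cc3)o2)n1`, gives 44 nM in this assay; the gap between them, a 4.9-fold lower number from compound 1 to compound 2 (0.69 log units; beyond the scatter), arises from methyl in place of hydrogen on an oxygen next to a carbonyl group.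

Compound 3 `COC(=O)c1cccc(-c2cnc(C(=O)CCc3ccc(-c4ccc(CN5CCCC5)cc4)cc3)o2)n1` differs from compound 2 by pyrrolidin-1-yl in place of piperidin-1-yl on a saturated chain carbon bound to an aromatic carbon. Among the compounds with values here, no measured step touches this part of the structure; the only step known, a 4.9-fold lower number from compound 1 to compound 2 (0.69 log units; beyond the scatter), concerns a different part of the molecule and so offers no direct guidance. The change exchanges one saturated nitrogen ring for a smaller one at the same place, and a step of no change at the digits printed from compound 2 to compound 3 (within the scatter) is expected, meaning none beyond the scatter. Compound 3 is therefore estimated to give 9 nM in this assay, with a range from 3 nM to 30 nM.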

Compound 3, inhibition constant: 18 nM
Compound 3: the middle estimate sits 2.0-fold (0.30 log units) below what was measured; the range from low to high includes it.
By their numbers in this assay, from the lowest: compounds 2 and 3 (each within the scatter of the next); then compound 1.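

In this assay, going by these compounds alone, the terminal amine ring gives the first reading at this place, on a saturated chain carbon bound to an aromatic carbon: pyrrolidin-1-yl in place of piperidin-1-yl gives a 2.0-fold higher number from compound 2 to compound 3 (0.30 log units; within the scatter) and so stays within the scatter. With the methyl ester held in both compounds, the five-membered and six-membered rings therefore cannot be told apart in this assay, so this one pair shows no dependence on ring size at this place. No measurement offered here bears on why the two compounds read alike.

Still open, from the compounds shown here alone, is how an azepan-1-yl, a morpholin-4-yl or an open-chain dimethylamino group would read at this place. Also open, going by these compounds, is whether pyrrolidin-1-yl would give a similar step alongside the carboxylic acid of compound 1.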